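The compounds below may be only part of what the source reports. "The series", "measured", "known", "first", "only" and "open" are said of these compounds alone.

Values in a functional assay, read by fluorescence and spectrophotometry, with a stated time of 1 h; on this read-out higher numbers stand for an effect only at larger amounts of compound and lower numbers for an effect already at smaller amounts:
- compound 1 `O=S(=O)(/C=C/c1ccc(O)c(O)c1)CCC1CCCCC1`: 9800 nM
- compound 2 `CCCCCS(=O)(=O)/C=C/c1ccc(O)c(O)c1`: 8100 nM
- compound 3 `O=S(=O)(/C=C/c1ccc(O)c(O)c1)CC1CCCCO1`: 10800 nM
- compound 4 `CCCCCCCCS(=O)(=O)/C=C/c1ccc(O)c(O)c1`: not yet measured

Compound 3 stands level with the other two compounds, with a 1.1-fold higher number from compound 1 to compound 3 (0.04 log units; within the scatter) and a 1.3-fold higher number from compound 2 to compound 3 (0.12 log units; within the scatter). The remaining pair shows a 1.2-fold lower number from compound 1 to compound 2 (0.08 log units; within the scatter).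

The next change is heptyl in place of oxan-2-yl on a saturated chain carbon bound to a sulfonyl sulfur. The two steps to compound 3 bear on it most directly, since both changed that same place and neither left the scatter. Among the measured compounds shown here, no measured compound carries heptyl, so this remains an extrapolation.

No step beyond the scatter is expected in this assay, and the expected step is a 1.3-fold lower number from compound 3 to compound 4 (0.10 log units; within the scatter). For compound 4 the estimate is 8500 nM, with an expected range of 4000 nM to 16000 nM.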

Compound 4, half-maximal effective concentration: 6400 nM
Estimate against measurement, compound 4: 1.3-fold (0.12 log units) above; measured number inside the range.
By their numbers in this assay, from the lowest: compounds 4, 2, 1 and 3 (each within the scatter of the next).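

In this assay the open heptyl chain sits level with the ring-bearing and shorter-chain compounds at this position: a 1.7-fold lower number from compound 3 to compound 4 (0.23 log units; within the scatter), a 1.3-fold lower number from compound 2 to compound 4 (0.10 log units; within the scatter) and a 1.5-fold lower number from compound 1 to compound 4 (0.19 log units; within the scatter). Giving up the oxan-2-yl ring with its oxygen, or extending the pentyl chain of compound 2 by propyl, therefore moves the number by no more than the scatter. Nothing available accounts for this flat picture.

Going by these compounds, whether an amine or a carboxylic acid on this chain would leave the scatter remains open. So does the outcome for a chain longer than the one in compound 4.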